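Side-chain variation at the amine of the shared core

This account rests on a few compounds, and the source may have more. Where it says the series, first, only, none or still open, it means among the compounds named here.

Compound 2 `COc1ccc(/C=C\c2cc(OC)c(OC)c(OC)c2)cc1OCc1ccc(CNCCO)cc1` gives 6600 nM in a functional assay on B16-F10 cells (Mus musculus) for antiproliferative activity, read by CCK-8 assay, with a stated time of 48 h (on this read-out higher numbers stand for weaker inhibition and lower numbers for stronger inhibition), and stands within the scatter of its only comparator. In this assay compound 1 `COc1ccc(/C=C\c2cc(OC)c(OC)c(OC)c2)cc1OCc1ccc(CN[C@H](C(=O)O)[C@@H](C)O)cc1` gives 5400 nM. Within the data shown here, the single measured step, a 1.2-fold higher number from compound 1 to compound 2 (0.09 log units; within the scatter), concerns a different replacement on the same amine nitrogen and moved nothing beyond the scatter. Compound 3 `COc1ccc(/C=C\c2cc(OC)c(OC)c(OC)c2)cc1OCc1ccc(CNCCNC(C)=O)cc1` differs from compound 2 by acetamido in place of hydroxy on a saturated chain carbon, two bonds along the chain from an amine nitrogen. Among the measured compounds shown here, with only that flat step to lean on, the step from compound 2 to compound 3 is expected to be no change at the digits printed from compound 2 to compound 3 (within the scatter), no movement beyond the scatter. Compound 3 is estimated at 6600 nM, from 3000 nM to 14000 nM.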

Compound 3, half-maximal inhibitory concentration: 2500 nM
Estimate against measurement, compound 3: 2.6-fold (0.42 log units) above; measured number below the stated range.
By their numbers in this assay, from the lowest: compound 3; then compounds 1 and 2 (each within the scatter of the next).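

In this assay, among these compounds, the side chain on this amine nitrogen does affect the read-out: a 2.6-fold lower number from compound 2 to compound 3 (0.42 log units; beyond the scatter) is the first step here beyond the scatter, with acetamido in place of hydroxy on the saturated chain carbon. The 2-acetamidoethyl group also separates from the 1-carboxy-2-hydroxypropyl group, with a 2.2-fold lower number from compound 1 to compound 3 (0.33 log units; beyond the scatter) in the same direction, whereas 2-hydroxyethyl and 1-carboxy-2-hydroxypropyl stayed within the scatter of each other.

As far as these compounds go, whether a longer chain, a terminal amine or a carboxylic acid at this chain carbon would match compound 3 remains open. No measurement at hand gives a reason for the step.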